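Methoxy in Place of Propyl on a Shared Core

The source may hold more compounds than are shown below. What is called first, only, known or untested is meant among the compounds shown, and "the series" means these compounds.

Of the compounds shown here, two built on one core have been measured in an assay on membranes from brain for displacement of a labelled ligand from Neuronal acetylcholine receptor; alpha4/beta2 (Rattus norvegicus), with a stated time of 3 h; on this read-out lower numbers stand for stronger inhibition and higher numbers for weaker inhibition. Compound 1 `C(=C1\CCCN=C1c1cccnc1)\c1ccc(-n2ccnn2)cc1` carries a 1H-1,2,3-triazol-1-yl group on an aromatic carbon and gives 520 nM. Compound 2 `CCCc1ccc(/C=C2\CCCN=C2c2cccnc2)cc1` carries a propyl group on that aromatic carbon and gives 890 nM. Of the two numbers, that of compound 2 is the higher, but the step of a 1.7-fold higher number from compound 1 to compound 2 (0.23 log units; within the scatter) lies within the scatter, so the two compounds are not separated by this assay.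

Compound 3 `COc1ccc(/C=C2\CCCN=C2c2cccnc2)cc1` differs from compound 2 in a single place: methoxy in place of propyl on an aromatic carbon. For the measured compounds named here, only one measured step bears on this change, and it concerns a different pair of groups on the same aromatic carbon: exchanging the triazolyl group for propyl gave a 1.7-fold higher number from compound 1 to compound 2 (0.23 log units; within the scatter), a step within the scatter. Going by the values given here, no measured compound carries methoxy, so the expectation rests on the fact that a sizeable exchange at this carbon left the number nearly unchanged. The step is therefore expected to be small, a 1.3-fold lower number from compound 2 to compound 3 (0.10 log units; within the scatter), with no direction beyond the scatter. Compound 3 is estimated at 700 nM, expected to fall between 250 nM and 2500 nM.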

Compound 3, inhibition constant: 490 nM
Estimate against measurement, compound 3: 1.4-fold (0.15 log units) above; the range from low to high includes it.
By their numbers in this assay, from the lowest: compounds 3, 1 and 2 (each within the scatter of the next).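

In this assay, the step of a 1.8-fold lower number from compound 2 to compound 3 (0.26 log units; within the scatter) for methoxy in place of propyl and the step of a 1.1-fold lower number from compound 1 to compound 3 (0.03 log units; within the scatter) for methoxy in place of 1H-1,2,3-triazol-1-yl both stay within the scatter, so all three groups on this aromatic carbon, para to a large group, now stand within the scatter of one another. This adds a third group to the earlier pair, and methoxy differs from propyl in carrying oxygen and a hydrogen-bond acceptor, yet the assay does not separate compound 3 from either compound 2 or compound 1, so this position has so far shown no measurable preference among these groups. Nothing available here offers an explanation for how close these numbers lie.

The compounds shown leave open whether any group on this carbon can move the number beyond the scatter, in either direction. As far as these compounds go, how an amine, a carboxylic acid or a chain longer than propyl would read here remains unknown, as does whether methoxy would behave the same way on another carbon of this ring.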